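A few compounds are considered here, and "the series" means these few. Any claim that something is new, unique, unknown or untested is made for them only; others in the source may bear on it.

Measured compounds:
Compound 1 `Cn1cc(S(=O)(=O)N2CC(CNC(=O)c3ccc(Cl)cc3Cl)(CC3CC3)C2)cn1` gives 3.62 nM in an assay on JAR cells for inhibition of sodium- and chloride-dependent glycine transporter 1 (Homo sapiens), read by scintillation counting, with a stated time of 3 h; a lower number here means a stronger inhibitor, a higher number a weaker inhibitor.
Compound 2 `Cn1cc(S(=O)(=O)N2CCC(CNC(=O)c3ccc(Cl)cc3Cl)(CC3CC3)CC2)nn1` gives 32 nM in this assay.
Compound 3 `Cn1cc(S(=O)(=O)N2CCC(CNC(=O)c3ccc(Cl)cc3Cl)(CC3CC3)CC2)cn1` gives 10.4 nM in this assay.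

Compound 3 holds the middle place of the three numbers: compound 1 sits lower and compound 2 sits higher, both beyond the scatter. The single step that joins two of these compounds is a 3.1-fold lower number from compound 2 to compound 3 (0.49 log units; beyond the scatter). Compound 4 `CCn1cc(S(=O)(=O)N2CCC(CNC(=O)c3ccc(Cl)cc3Cl)(CC3CC3)CC2)nn1` differs from compound 3 by 1-ethyl-1H-1,2,3-triazol-4-yl in place of 1-methyl-1H-pyrazol-4-yl on a sulfonyl sulfur. For the measured compounds named here, the measured step from compound 2 to compound 3 bears on it in reverse, since it swaps the same two ring types on the same sulfonyl sulfur; the lengthening of the methyl to an ethyl has no measured counterpart here. A modest rise in this assay is therefore expected, a 2.9-fold higher number from compound 3 to compound 4 (0.46 log units; beyond the scatter), giving compound 4 an estimated 30 nM with a range from 12 nM to 75 nM.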

Compound 4, half-maximal inhibitory concentration: 28.2 nM
Compound 4: the middle estimate sits 1.1-fold (0.03 log units) above what was measured, and the stated range covers the measured number.
By their numbers in this assay, from the lowest: compound 1; then compound 3; then compounds 4 and 2 (each within the scatter of the next).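

In this assay, the ethyl in place of the methyl on the triazole nitrogen gives a 1.1-fold lower number from compound 2 to compound 4 (0.05 log units; within the scatter), so the chain length at this nitrogen, from methyl to ethyl, shows no separation beyond the scatter. The step of a 2.7-fold higher number from compound 3 to compound 4 (0.43 log units; beyond the scatter) therefore follows the 1,2,3-triazole in place of the pyrazole, not the ethyl. No supporting measurement accounts for either step. The compounds shown leave open whether a 1-ethyl-1H-pyrazol-4-yl group would keep the lower number of the pyrazole series, and whether a propyl or a cyclopropyl on the triazole nitrogen would extend this flat reading.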